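Microsomal clearance in a thiazolidinone amide series

The source may hold more compounds than are shown below. What is called first, only, known or untested is meant among the compounds shown, and "the series" means these compounds.

Measured so far:
compound 1, `O=C(NCCCCn1cccn1)c1cccc(C2SCC(=O)N2c2ccccn2)c1`, 304 mL.min-1.g-1
compound 2, `C#Cc1cccc(N2C(=O)CSC2c2cccc(C(=O)NCCCCc3ccccc3)c2)c1`, 1900 mL.min-1.g-1
compound 3, `COc1ccccc1N1C(=O)CSC1c1cc(F)cc(C(=O)NCCCCc2ccccc2)c1`, 1430 mL.min-1.g-1

The read-out is an ADME assay on microsomes from liver (Mus musculus) for metabolic stability, read by LC-MS, using NADPH, with a stated time of 10 min, tested at 0.1 uM; on this read-out higher numbers stand for fast clearance and lower numbers for slow clearance. Across the three numbers, compound 2 stands highest at 1900 mL.min-1.g-1. Its nearest neighbour is compound 3, whose 1430 mL.min-1.g-1 lies within the scatter of compound 2, so no order between them can be claimed. Compound 1 is furthest away at 304 mL.min-1.g-1, a gap beyond the scatter; compound 1 also differs from compound 2 in more than one place, so nothing is attributed to any single change there.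

Compound 4, `COc1ccc(F)cc1N1C(=O)CSC1c1cccc(C(=O)NCCCCc2ccccc2)c1`, is not yet measured in this assay. Relative to compound 2 it carries 5-fluoro-2-methoxyphenyl in place of 3-ethynylphenyl on an amide-type nitrogen in a ring. Within the data shown here, no measured pair isolates this change. Compound 3 already carries a methoxyphenyl group on the same nitrogen and gives 1430 mL.min-1.g-1, which is the main reference here.

Compound 4 is expected to remain in the fast-clearance region, estimated at 1400 mL.min-1.g-1 with a range of 700 mL.min-1.g-1 to 2800 mL.min-1.g-1. The expected 1.4-fold lower number from compound 2 to compound 4 (0.13 log units; within the scatter) is a small step downward, within the scatter, because compound 3 gives 1430 mL.min-1.g-1.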

Compound 4, intrinsic clearance in microsomes: 2250 mL.min-1.g-1
The estimate for compound 4 lay 1.6-fold (0.21 log units) below the measured number, and the stated range covers the measured number.
By their numbers in this assay, from the lowest: compound 1; then compounds 3, 2 and 4 (each within the scatter of the next).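

In this assay, among these compounds, the only comparison of compounds that differ in one place is a 1.2-fold higher number from compound 2 to compound 4 (0.07 log units; within the scatter), with 5-fluoro-2-methoxyphenyl in place of 3-ethynylphenyl on the amide-type nitrogen in the ring. The earlier compounds shown here offered no such pair; this one shows that, on this read-out, the two groups cannot be told apart, even though the exchange replaces a triple bond with a methoxy group and a fluorine and adds a hydrogen-bond acceptor. No supporting measurement bears on this result.

Going by these compounds, whether a group of a different kind on this nitrogen, such as a phenyl ring carrying a carboxylic acid or a tertiary amine, would give a step beyond the scatter remains open. The separate contributions of the fluorine and the methoxy group also remain unresolved, as no pair shown isolates either one.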